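The compounds below may be only part of what the source reports. "The series", "measured", "known", "first", "only" and "open" are said of these compounds alone.

In a toxicity assay on Vero cells (Chlorocebus sabaeus) for cytotoxicity, read by MTT assay (a lower number here means a stronger inhibitor, a higher number a weaker inhibitor), three compounds with a shared core differ only in the group on a sulfonyl sulfur. Compound 1 `CCOC(=O)NC(=O)c1ccsc1NC(=O)c1ccc(S(=O)(=O)N2CCCC2)cc1`, with pyrrolidin-1-yl, gives 58.2 ug/mL. Compound 2 `CCOC(=O)NC(=O)c1ccsc1NC(=O)c1ccc(S(=O)(=O)N2CCCCC2)cc1`, with piperidin-1-yl, gives 18.6 ug/mL. Compound 3 `CCOC(=O)NC(=O)c1ccsc1NC(=O)c1ccc(S(=O)(=O)N2CCCCCC2)cc1`, with azepan-1-yl, gives 3.42 ug/mL, the lowest number of the three. The next compound, compound 4 `CCOC(=O)NC(=O)c1ccsc1NC(=O)c1ccc(S(=O)(=O)N2CCC(OC)CC2)cc1`, carries 4-methoxypiperidin-1-yl in place of azepan-1-yl on a sulfonyl sulfur.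

The closest measured guide is a 5.4-fold lower number from compound 2 to compound 3 (0.74 log units; beyond the scatter), a modest change for azepan-1-yl in place of piperidin-1-yl. Also relevant are a 3.1-fold lower number from compound 1 to compound 2 (0.50 log units; beyond the scatter), likewise modest, and a 17-fold lower number from compound 1 to compound 3 (1.23 log units; beyond the scatter), which is large. Among the measured compounds shown here, no measured compound carries a methoxy group, so its contribution is unknown. Since compound 4 keeps a six-membered group, a modest rise in this assay is expected, back towards the number of compound 2 at 18.6 ug/mL. The expected step is a 4.1-fold higher number from compound 3 to compound 4 (0.61 log units; beyond the scatter). For compound 4 the estimated value is 14 ug/mL, within an expected range from 5 ug/mL to 40 ug/mL.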

Compound 4, half-maximal inhibitory concentration: 21 ug/mL
Beside the measured number, compound 4's estimate is 1.5-fold (0.18 log units) below it; measured number inside the range.
By their numbers in this assay, from the lowest: compound 3; then compounds 2 and 4 (each within the scatter of the next); then compound 1.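

In this assay, among the compounds shown here, the step of a 1.1-fold higher number from compound 2 to compound 4 (0.05 log units; within the scatter) gives the first reading of methoxy in place of hydrogen on a saturated ring carbon of the group on the sulfonyl sulfur, and it shows no change that can be told from the scatter. The steps of a 6.1-fold higher number from compound 3 to compound 4 (0.79 log units; beyond the scatter) and a 2.8-fold lower number from compound 1 to compound 4 (0.44 log units; beyond the scatter) show that ring size still orders these four compounds, whereas heavy-atom count does not: 4-methoxypiperidin-1-yl has more heavy atoms than azepan-1-yl, yet compound 4 does not follow compound 3 to the low end. No measurement given here explains these numbers.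

On these data alone, it remains open whether a hydroxy group or a primary amine on that ring carbon would also leave the number where the methoxy group does. As far as these compounds go, it is equally open whether a methoxy group on azepan-1-yl would keep the low number of compound 3.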